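Naphthylmethyl thioether replaces methylbenzyl on the sulfonyl core

The source may hold more compounds than are shown below. What is called first, only, known or untested is meant among the compounds shown, and "the series" means these compounds.

Compound 1 `Cc1cccc(CSc2cc(Cl)c(C)cc2S(=O)(=O)/N=C(\N)n2nccc2-c2ccccc2)c1` gives 8000 nM in a functional assay on HeLa cells (Homo sapiens) for cytotoxicity, read by MTT assay, with a stated time of 72 h (on this read-out lower numbers stand for stronger inhibition and higher numbers for weaker inhibition), the lower of the two numbers measured. Compound 2 `Cc1cccc(CSc2cc(Cl)c(C)cc2S(=O)(=O)/N=C(\N)n2nc(C)cc2-c2ccccc2)c1` gives 155000 nM in this assay, and the step of a 19-fold higher number from compound 1 to compound 2 (1.29 log units; beyond the scatter) came from a methyl in place of hydrogen on an aromatic carbon. Compound 3 `Cc1cc(S(=O)(=O)/N=C(\N)n2nccc2-c2ccccc2)c(SCc2cccc3ccccc23)cc1Cl` differs from compound 1 by naphthalen-1-yl in place of 3-methylphenyl on a saturated chain carbon bound to a sulfur. Within the data shown here, no measured step touches that part of the core, so the only known step does not bear on it. Compound 3 is therefore expected to show a step of no change at the digits printed from compound 1 to compound 3 (within the scatter), none beyond the scatter, with an estimate of 8000 nM ranging from 2000 nM to 32000 nM.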

Compound 3, half-maximal inhibitory concentration: 3000 nM
Estimate against measurement, compound 3: 2.7-fold (0.43 log units) above, and the stated range covers the measured number.
By their numbers in this assay, from the lowest: compound 3; then compound 1; then compound 2.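

In this assay, naphthalen-1-yl in place of 3-methylphenyl on a saturated chain carbon bound to a sulfur gives a 2.7-fold lower number from compound 1 to compound 3 (0.43 log units; beyond the scatter), so this position accepts a second aromatic ring and the number still falls modestly. The earlier step concerned only a methyl on an aromatic carbon and moved the number the other way. No available evidence accounts for the change at this position.

As far as these compounds go, it remains open whether naphthalen-2-yl, a plain benzyl or a longer chain before the ring would give a lower number. Also open, from the compounds shown here alone, is whether an amine on the ring would be tolerated.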